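Swapping difluorophenyl for cyanophenyl on a shared core

A few compounds are considered here, and "the series" means these few. Any claim that something is new, unique, unknown or untested is made for them only; others in the source may bear on it.

In a functional assay on KB cells (Homo sapiens) for antiproliferative activity (on this read-out lower numbers stand for stronger inhibition and higher numbers for weaker inhibition), compound 1 `COc1ccc(S(=O)(=O)N2CCc3cccc(Nc4ccc(O)cc4)c32)cc1`, with a 4-hydroxyphenyl group on the nitrogen, gives 239 nM. Compound 2 `COc1ccc(S(=O)(=O)N2CCc3cccc(Nc4ccc(F)cc4)c32)cc1`, with fluoro in place of hydroxy, gives 557 nM, and compound 3 `COc1ccc(S(=O)(=O)N2CCc3cccc(Nc4ccc(F)c(F)c4)c32)cc1`, with a 3,4-difluorophenyl group, gives 412 nM. Compound 3 cannot be told apart from either of the other two, since the measured steps to it are a 1.4-fold lower number from compound 2 to compound 3 (0.13 log units; within the scatter) and a 1.7-fold higher number from compound 1 to compound 3 (0.24 log units; within the scatter), both within the scatter.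

The next structure is compound 4 `COc1ccc(S(=O)(=O)N2CCc3cccc(Nc4ccc(C#N)cc4)c32)cc1`, and the change is 4-cyanophenyl in place of 3,4-difluorophenyl on a nitrogen on an aromatic ring. In words, it has 4-cyanophenyl in place of 3,4-difluorophenyl on a nitrogen on an aromatic ring. Among the compounds with values here, no measured step makes this exact swap, so the nearest guides are the other changes to the group on that nitrogen. The largest of these is a 2.3-fold higher number from compound 1 to compound 2 (0.37 log units; beyond the scatter), which is modest and involves the loss of the hydroxy group of compound 1. Compound 3 has no hydroxy group to lose, and adding a fluoro gave only a 1.4-fold lower number from compound 2 to compound 3 (0.13 log units; within the scatter). No change beyond the scatter is therefore expected in this assay, in either direction. The expected step is a 1.0-fold lower number from compound 3 to compound 4 (0.01 log units; within the scatter). Compound 4 is estimated at 400 nM, with an expected range of 170 nM to 950 nM.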

Compound 4, half-maximal inhibitory concentration: 49.7 nM
Compound 4: middle estimate off by 8.0-fold (0.91 log units), on the high side; the measured number lies below the stated range.
By their numbers in this assay, from the lowest: compound 4; then compounds 1, 3 and 2 (each within the scatter of the next, the first and the last beyond it).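

In this assay, within the data shown here, the group on this nitrogen proves able to shift the number much further than the earlier compounds showed: replacing fluoro with cyano gives an 11-fold lower number from compound 2 to compound 4 (1.05 log units; beyond the scatter), and the full swap of the aromatic group gives an 8.3-fold lower number from compound 3 to compound 4 (0.92 log units; beyond the scatter). Cyano also improves on hydroxy, the best of the earlier groups, with a 4.8-fold lower number from compound 1 to compound 4 (0.68 log units; beyond the scatter), so a step beyond the scatter separates compound 4 from each of the other three and it is the most potent of the four on this read-out. The entering 4-cyanophenyl group counts a triple bond and a hydrogen-bond acceptor that the leaving 3,4-difluorophenyl group lacks, but nothing available here shows which feature, if either, accounts for the gain.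

On these data alone, it remains open whether the nitrile is specifically required, which a 4-acetylphenyl, 4-carboxyphenyl or 4-aminophenyl group on the same nitrogen would help to test. As far as these compounds go, it is also open whether the same gain would hold if the methoxy group elsewhere on the shared core were replaced by, for example, an ethoxy group.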